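Swapping pyrazin-2-yl for pyrimidin-4-yl on a sulfonamide

The source may hold more compounds than are shown below. What is called first, only, known or untested is meant among the compounds shown, and "the series" means these compounds.

In a physicochemical assay for lipophilicity (a higher number here means a more lipophilic compound, a lower number a more polar compound), three compounds with a shared core have been measured, and they differ only in the ring on the sulfonamide nitrogen. Compound 1 `Cn1nccc1-c1cc(C(F)(F)F)ccc1[C@H]1CCOc2cc(S(=O)(=O)Nc3nccs3)ccc21` gives 2.2 and compound 2 `Cn1nccc1-c1cc(C(F)(F)F)ccc1[C@H]1CCOc2cc(S(=O)(=O)Nc3ccc(F)cn3)ccc21` gives 3.8 while compound 3 `Cn1nccc1-c1cc(C(F)(F)F)ccc1[C@H]1CCOc2cc(S(=O)(=O)Nc3cnccn3)ccc21` stands lowest of the three at 1.8 on this scale. Compound 4 `Cn1nccc1-c1cc(C(F)(F)F)ccc1[C@H]1CCOc2cc(S(=O)(=O)Nc3ccncn3)ccc21` carries pyrimidin-4-yl in place of pyrazin-2-yl on a sulfonamide nitrogen so the two groups have the same atoms, joined differently. For the measured compounds named here, no measured step makes this exact swap, and the nearest evidence comes from other ring swaps at that place. Two are large (a number 1.60 log units higher from compound 1 to compound 2 (beyond the scatter) and a number 2.00 log units lower from compound 2 to compound 3 (beyond the scatter)) and one is modest (a number 0.40 log units lower from compound 1 to compound 3 (beyond the scatter)). Both large steps involve compound 2 and its 5-fluoropyridin-2-yl group, so the modest step is the closer guide. Only a small shift is expected, with no firm direction, and the estimated step is a number 0.10 log units lower from compound 3 to compound 4 (within the scatter) in all likelihood. For compound 4 the expected value is 1.7 (estimated range 1.2 to 2.3).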

Compound 4, distribution coefficient: 1.8
Estimate against measurement, compound 4: 0.10 log units below; the measured number falls inside the stated range.
By their numbers in this assay, from the lowest: compounds 3 and 4 (each within the scatter of the next); then compound 1; then compound 2.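

In this assay, joining the same ring atoms differently has no visible effect at this position, with no change at the digits printed from compound 3 to compound 4 (within the scatter). Pyrimidin-4-yl also stands apart from the other two rings, with a number 2.00 log units lower from compound 2 to compound 4 (beyond the scatter) and a number 0.40 log units lower from compound 1 to compound 4 (beyond the scatter), and these steps match in size those already seen for pyrazin-2-yl, so the two rings cannot be told apart by this measurement. Nothing measured here bears on why these two rings read alike.

On these data alone, whether a third arrangement of the same atoms, pyridazin-3-yl, would give a similar number remains open. Also open, as far as these compounds go, is how far an amine or a methoxy group added to the pyrimidin-4-yl ring would move the number in this assay.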